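Bromo for methoxy: expected whole-animal read-out for compound 3

The source may report more compounds than this note shows. Statements on the series, on what has been measured and on what is new or still open speak of the compounds shown alone.

Two members of the series have been run so far. Compound 1 `COc1ccc(OCC2=NCCO2)cc1` and compound 2 `Clc1ccccc1OCC1=NCCO1` were tested in a toxicity assay on the whole organism with Rattus norvegicus as the target, at a dose of 200 mg/kg by the oral route; on this read-out higher numbers stand for a stronger effect at the one dose given and lower numbers for a weaker effect. In this assay compound 1 gives 10%, the lower of the two numbers recorded; compound 2 gives 30%, which lies above it by more than the usual scatter. These two compounds differ in more than one place, so their values do not define a single step.

Compound 3 `Brc1ccc(OCC2=NCCO2)cc1` is the next entry and has not been measured. It differs from compound 1 in one place: bromo in place of methoxy on an aromatic carbon. Going by the values given here, no measured pair isolates this change, so the size of the step in this assay is uncertain; a modest rise is expected rather than no change, since the other halogen-bearing member, compound 2, gives 30%. For compound 3 the expected value in this assay is 25%, with a range from 5% to 50%. This estimate corresponds to a step of a number 15 percentage points higher from compound 1 to compound 3 (beyond the scatter), expected to sit at the edge of the scatter.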

Compound 3, a percentage reported as activity, at one dose (the size of the read-out at that dose, not a potency): 10%
Compound 3: middle estimate off by 15 percentage points, on the high side; the range from low to high includes it.
By their numbers in this assay, from the lowest: compounds 1 and 3 (each within the scatter of the next); then compound 2.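

In this assay, going by these compounds alone, the first single-place step is no change at the digits printed from compound 1 to compound 3 (within the scatter), for bromo in place of methoxy on an aromatic carbon. At this place, para to a group of 7 heavy atoms, the read-out therefore does not separate methoxy, with its 2 heavy atoms and 1 hydrogen-bond acceptor, from bromo, with 1 heavy atom and no acceptor; steps involving compound 2 cannot be read, as it differs from both compounds in more than one place. No measurement shown bears on the reason for this result.

Open, from the compounds shown here alone, is whether an amine or a carboxylic acid on this same aromatic carbon would move the read-out beyond the scatter. A longer chain, such as butoxy, at this place also remains untested in the compounds shown.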